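Fluoro for chloro: expected tolerance of compound 4

A few compounds are considered here, and "the series" means these few. Any claim that something is new, unique, unknown or untested is made for them only; others in the source may bear on it.

Among the measured compounds shown here, three analogues on a shared core have numbers so far. Compound 1 `Cc1ccc(/C=C/C(=O)NNC(=O)c2ccc3c(c2)OCCO3)cc1` gives 332000 nM in an ADME assay on cells (Macrophage) for cytotoxicity, read by MTT assay, with a stated time of 24 h; a higher number here means that more compound is tolerated, a lower number that less compound is tolerated. Compound 2 `O=C(/C=C/c1ccc(F)cc1)NNC(=O)c1ccc2c(c1)OCCO2` gives 319000 nM in this assay, and compound 3 `O=C(/C=C/c1cccc(Cl)c1)NNC(=O)c1ccc2c(c1)OCCO2` gives 391000 nM. Compound 3 stands within the scatter of both neighbours: the step of a 1.2-fold higher number from compound 1 to compound 3 (0.07 log units; within the scatter) and the step of a 1.2-fold higher number from compound 2 to compound 3 (0.09 log units; within the scatter) are both within the scatter, as is the step of a 1.0-fold lower number from compound 1 to compound 2 (0.02 log units; within the scatter), so the three values cannot be told apart in this assay.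

Compound 4 `O=C(/C=C/c1cccc(F)c1)NNC(=O)c1ccc2c(c1)OCCO2` differs from compound 3 by fluoro in place of chloro on an aromatic carbon. The precedents that bear on it are the substituent exchange on the aromatic carbon, a 1.0-fold lower number from compound 1 to compound 2 (0.02 log units; within the scatter), and the aryl exchanges a 1.2-fold higher number from compound 1 to compound 3 (0.07 log units; within the scatter) and a 1.2-fold higher number from compound 2 to compound 3 (0.09 log units; within the scatter); none of them left the scatter. A change of the same kind is therefore expected to leave the number essentially where it is, and the expected step is a 1.1-fold lower number from compound 3 to compound 4 (0.05 log units; within the scatter), no movement beyond the scatter in either direction. Compound 4 is expected to give 350000 nM in this assay, with a range from 230000 nM to 530000 nM.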

Compound 4, half-maximal cytotoxic concentration: 221000 nM
Estimate against measurement, compound 4: 1.6-fold (0.20 log units) above; measured number below the stated range.
By their numbers in this assay, from the lowest: compounds 4, 2, 1 and 3 (each within the scatter of the next).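

Chloro to fluoro on this aromatic carbon gives a 1.8-fold lower number from compound 3 to compound 4 (0.25 log units; within the scatter) in this assay and is the only exchange of one halogen for another shown at this position, so that exchange cannot be separated from no change. With the halogen held as fluoro, 3-fluorophenyl in place of 4-fluorophenyl gives a 1.4-fold lower number from compound 2 to compound 4 (0.16 log units; within the scatter) in this assay and 3-fluorophenyl in place of 4-methylphenyl gives a 1.5-fold lower number from compound 1 to compound 4 (0.18 log units; within the scatter) in the same assay, which leaves all four compounds a single group, with no preference readable for the aryl groups shown. No available data bear on the cause of these small differences.

As far as these compounds go, whether an amine or a carboxylic acid on this aromatic carbon would move the number beyond the scatter remains open. From the compounds shown here alone, all four compounds also share one core, so the effect of changing it remains unknown.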